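The source may report more compounds than this note shows. Statements on the series, on what has been measured and on what is new or still open speak of the compounds shown alone.

Compound 3 `O=c1sc2cc(NS(=O)(=O)c3ccccc3)ccc2n1CCN1CCCCC1` stands second highest of the three numbers in an assay on HEK293 cells for displacement of a labelled ligand from 5-hydroxytryptamine receptor 6 (Homo sapiens), read by radioligand binding, with a stated time of 60 min, tested at 100 nM (a lower number here means less inhibition, a higher number more inhibition at the concentration tested (going by the name of the read-out)), where compound 3 gives 6%. Its nearest neighbour is compound 2 `CN(C)CCn1c(=O)sc2cc(NS(=O)(=O)c3ccccc3)ccc21`, which gives 5%; the step of a number 1 percentage points higher from compound 2 to compound 3 (within the scatter) lies within the scatter. Compound 1 `CN(C)CCn1c(=O)sc2cc(S(=O)(=O)c3ccccc3)ccc21` gives 16%, a value that stands within the scatter of compound 3. Compound 4 `O=c1sc2cc(NS(=O)(=O)c3ccc4ccccc4c3)ccc2n1CCN1CCCCC1` differs from compound 3 by naphthalen-2-yl in place of phenyl on a sulfonyl sulfur. Among the measured compounds shown here, no measured step concerns the group on the sulfonyl sulfur, so nothing among the measured compounds bears directly on this change; the one measured step, a number 1 percentage points higher from compound 2 to compound 3 (within the scatter), concerns the amine on the chain and is itself within the scatter. A step of a number 2 percentage points higher from compound 3 to compound 4 (within the scatter) is therefore expected, none beyond the scatter. Compound 4 is estimated at 8%, with a range from 0% to 25%.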

Compound 4, a percentage reported as inhibition, at one concentration (the size of the read-out at that concentration, not a potency): 4%
Beside the measured number, compound 4's estimate is 4 percentage points above it; the range from low to high includes it.
By their numbers in this assay, from the lowest: compounds 4, 2, 3 and 1 (each within the scatter of the next, the first and the last beyond it).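

In this assay, among the compounds shown here, naphthalen-2-yl in place of phenyl on a sulfonyl sulfur brings a number 2 percentage points lower from compound 3 to compound 4 (within the scatter) and gives the first reading at this position. With the piperidin-1-yl chain held fixed, the second six-membered aromatic ring does not separate the two compounds beyond the scatter. No measured evidence bears on this result. Going by these compounds, it remains open whether a different group on the sulfonyl sulfur, such as methyl or pyridin-3-yl, would separate from phenyl, and whether a longer chain carrying the piperidine would do so.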